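This account rests on a few compounds, and the source may have more. Where it says the series, first, only, none or still open, it means among the compounds named here.

In a functional assay on LNCaP cells (Homo sapiens) for antiproliferative activity (on this read-out lower numbers stand for stronger inhibition and higher numbers for weaker inhibition), three compounds have been measured so far:

Compound 1 `Cn1ncc(Cl)c1-c1cc(C(=O)N[C@@H]2CN[C@H](CCN3CCCCC3)C[C@H]2c2ccc(Cl)c(Cl)c2)oc1Cl`: 1780 nM
Compound 2 `Cn1ncc(Cl)c1-c1cc(C(=O)N[C@@H]2CN[C@H](CC(N)=O)C[C@H]2c2ccc(Cl)c(Cl)c2)oc1Cl`: 160 nM
Compound 3 `CN(C)CC[C@@H]1C[C@@H](c2ccc(Cl)c(Cl)c2)[C@H](NC(=O)c2cc(-c3c(Cl)cnn3C)c(Cl)o2)CN1`: 1930 nM

Compound 3 stands at the high end of these numbers, level with compound 1: a 1.1-fold higher number from compound 1 to compound 3 (0.04 log units; within the scatter). The next compound, compound 4 `Cn1ncc(Cl)c1-c1cc(C(=O)N[C@@H]2CN[C@H](CC(=O)NC3CC3)C[C@H]2c2ccc(Cl)c(Cl)c2)oc1Cl`, differs from compound 3 as follows: cyclopropylcarbamoyl in place of (dimethylamino)methyl on a saturated chain carbon bound to a saturated ring carbon. In words, cyclopropylcarbamoyl takes the place of (dimethylamino)methyl. The closest evidence comes from the carbamoyl compound 2, seen in two large steps: an 11-fold lower number from compound 1 to compound 2 (1.05 log units; beyond the scatter) and a 12-fold higher number from compound 2 to compound 3 (1.08 log units; beyond the scatter). For the measured compounds named here, no measured compound carries the cyclopropyl ring, which widens the uncertainty. The step expected in this assay is nevertheless large and towards stronger inhibition: an 8.8-fold lower number from compound 3 to compound 4 (0.94 log units; beyond the scatter). Compound 4 is estimated at 220 nM, with an expected range of 70 nM to 700 nM.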

Compound 4, half-maximal inhibitory concentration: 190 nM
Compound 4: middle estimate off by 1.2-fold (0.06 log units), on the high side; the measured number falls inside the stated range.
By their numbers in this assay, from the lowest: compounds 2 and 4 (each within the scatter of the next); then compounds 1 and 3 (each within the scatter of the next).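

In this assay the amide hydrogen of compound 2 can give way to a cyclopropyl ring while the number stays level, with a 1.2-fold higher number from compound 2 to compound 4 (0.07 log units; within the scatter) as the step. So this position accepts a substituted amide, and the gap to the amine chains holds, with a 10-fold lower number from compound 3 to compound 4 (1.01 log units; beyond the scatter) and a 9.4-fold lower number from compound 1 to compound 4 (0.97 log units; beyond the scatter) as the steps. No further evidence bears on this result.

Still open, from the compounds shown here alone, is whether a larger group on the amide nitrogen, such as a phenyl ring, keeps this level. Going by these compounds, a carboxylic acid in place of the amide is equally open.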